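A few compounds are considered here, and "the series" means these few. Any claim that something is new, unique, unknown or untested is made for them only; others in the source may bear on it.

Measured so far:
Compound 1 `COc1ccn2ncc(/C=N/N(C)S(=O)(=O)c3cc([N+](=O)[O-])ccc3C)c2c1` — in an assay on isolated protein for inhibition of phosphatidylinositol 4,5-bisphosphate 3-kinase catalytic subunit beta isoform (Homo sapiens), read by 33P incorporation, with a stated time of 60 min (on this read-out lower numbers stand for stronger inhibition and higher numbers for weaker inhibition), compound 1 gives > 1000 nM, a limit of the assay.
Compound 2 `Cc1ccc([N+](=O)[O-])cc1S(=O)(=O)N(C)/N=C/c1cnn2cc(Br)ccc12` — in this assay compound 2 gives > 1000 nM, again a limit.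
Compound 3 `Cc1ccc([N+](=O)[O-])cc1S(=O)(=O)N(C)/N=C/c1cnn2cccc(Br)c12` — in this assay compound 3 gives > 1000 nM, likewise a limit.

Compound 1 therefore stands at the limit of > 1000 nM in this assay, at which 3 of the 3 values shown sit, and none of the three compounds shows a number that would set one apart from the others. Compound 4 `Cc1ccc([N+](=O)[O-])cc1S(=O)(=O)N(C)/N=C/c1cnn2ccc(Cl)cc12` differs from compound 1 by chloro in place of methoxy on an aromatic carbon. Within the data shown here, no step between measured compounds is available to gauge this change, so no shift beyond the scatter is expected in this assay. Compound 4 is estimated at 3000 nM (range 800 nM to 15000 nM), which is expected to mean the step that the limit leaves unreadable from compound 1 to compound 4, most probably reported once more only as a limit.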

Compound 4, half-maximal inhibitory concentration: 390 nM
Compound 4: middle estimate off by 7.7-fold (0.89 log units), on the high side, outside the stated range (below it).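

In this assay, chloro in place of methoxy on this aromatic carbon, opposite the ring nitrogen, gives an at least 2.5-fold lower number from compound 1 to compound 4 (0.40 log units; beyond the scatter), which shows that inhibition responds to the group held at this position. The size of this step is only a lower bound, as compound 1 has a limit rather than a number. Compound 4 alone gives a readable number, and it stands apart from the rest: the limit of > 1000 nM in this assay, at which 3 of the 4 values shown sit.

On these data alone, how far the step truly runs remains open. So does what fluoro, methyl, a nitrile or an amine would give on this same carbon.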